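A few compounds are considered here, and "the series" means these few. Any claim that something is new, unique, unknown or untested is made for them only; others in the source may bear on it.

Compound 1 `COc1cccc2occ(Cc3coc4ccccc4c3=O)c(=O)c12` belongs to a small set of analogues examined in a functional assay on HCT-15 cells (Homo sapiens) for antiproliferative activity, read by XTT assay; a lower number here means a stronger inhibitor, a higher number a weaker inhibitor. In this assay compound 1 gives 3430 nM. The two related compounds, compound 2 `O=c1c(Cc2coc3cccc(OCC4CCCCC4)c3c2=O)coc2cc(O)ccc12` and compound 3 `Cc1ccc2c(=O)c(Cc3coc4cccc(OCC5CCCCC5)c4c3=O)coc2c1`, both carry a cyclohexylmethoxy group on the same ring position where compound 1 bears its methoxy, and each differs from compound 1 in a second place as well; compound 2 gives 2110 nM and compound 3 gives 2220 nM in this assay. Their difference from compound 1 is within the scatter. Among the compounds with values here, the only single-point step available, a 1.1-fold higher number from compound 2 to compound 3 (0.02 log units; within the scatter), concerns the other ring and does not bear on the change at hand.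

Compound 4 `CC(C)CCOc1cccc2occ(Cc3coc4ccccc4c3=O)c(=O)c12` differs from compound 1 as follows: isobutyl in place of hydrogen on a saturated chain carbon bound to an oxygen on an aromatic ring. Within the data shown here, no measured step isolates this change. Compounds 2 and 3 show that a bulkier alkoxy group in that position leaves the number within the scatter of compound 1, so no step beyond the scatter is expected for a 1.4-fold lower number from compound 1 to compound 4 (0.14 log units; within the scatter). Compound 4 is therefore estimated at 2500 nM, with a range from 900 nM to 7000 nM.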

Compound 4, half-maximal inhibitory concentration: > 10000 nM
Compound 4 gave a limit, no number; the forecaster's own chance of this, stated with the estimate: 5%; middle value at least 4.0-fold (0.60 log units) from the limit.
By their numbers in this assay, from the lowest: compounds 2, 3 and 1 (each within the scatter of the next). At a limit, above all of these: compound 4.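

In this assay compound 4 gives > 10000 nM, which is a limit of the assay and not a number. Going from methoxy to isopentyloxy on the shared core gives an at least 2.9-fold higher number from compound 1 to compound 4 (0.46 log units; beyond the scatter), the first step that isolates this position, and it shows that the number here does respond to the alkoxy chain, which the compounds carrying cyclohexylmethoxy could not show, each differing in a second place as well. The true size of the step stays unknown because only a limit stands at its upper end: the limit of > 10000 nM in this assay, at which 1 of the 4 values shown sits.

Going by these compounds, with a single chain tested in this comparison, it remains open whether the length of the chain or its branching matters. Whether an ethoxy group, an unbranched pentyloxy chain, or a chain ending in an amine or a carboxylic acid would stay close to compound 1 is also left open.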